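2-Hydroxyethyl to hydroxymethyl: compound 3 to compound 4

This account rests on a few compounds, and the source may have more. Where it says the series, first, only, none or still open, it means among the compounds named here.

Of the compounds shown here, three sharing one core have been tested so far in an ADME assay on Vero cells (Chlorocebus sabaeus) for cytotoxicity, read by MTT assay, with a stated time of 24 h; on this read-out higher numbers stand for lower toxicity in this test and lower numbers for higher toxicity in this test. Compound 1 `Cn1nc(C(F)(F)F)cc1C(=O)Nc1ccc(S(=O)(=O)N2CCCCC2)cc1` gives > 75000 nM, which is a limit and not a number. Compound 2 `Cn1nc(C(F)(F)F)cc1C(=O)Nc1ccc(S(=O)(=O)c2ccccc2CO)cc1` gives > 75000 nM, again a limit. Compound 3 `Cn1nc(C(F)(F)F)cc1C(=O)Nc1ccc(S(=O)(=O)N2CCCCC2CCO)cc1` gives > 75000 nM, also a limit, so it has no measured number of its own. All readings so far coincide: the limit of > 75000 nM in this assay, at which 3 of the 3 values shown sit.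

Compound 4 `Cn1nc(C(F)(F)F)cc1C(=O)Nc1ccc(S(=O)(=O)N2CCCCC2CO)cc1` remains to be measured. It carries hydroxy in place of hydroxymethyl on a saturated chain carbon bound to a saturated ring carbon. Cut one bond further out, this reads 2-hydroxyethyl to hydroxymethyl.

The closest measured change is a step that the two limits leave unreadable from compound 1 to compound 3, with 2-hydroxyethyl in place of hydrogen on a saturated ring carbon. Further off lie a step that the two limits leave unreadable from compound 1 to compound 2 and a step that the two limits leave unreadable from compound 2 to compound 3, both changes on a sulfonyl sulfur. None of the three has a readable size, so none supplies a direction. In this assay, nothing beyond the usual scatter is therefore expected, and a further limit reading is the likeliest outcome. The expected step is a step that the limit leaves unreadable from compound 3 to compound 4. For compound 4 the estimate is 100000 nM, with an expected range of 60000 nM to 250000 nM.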

Compound 4, half-maximal cytotoxic concentration in the Vero assay: > 75000 nM
Compound 4: a limit, no number; the forecaster's own chance of this, stated with the estimate: 85%; the middle value does not contradict the limit.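

In the Vero assay compound 4 gives > 75000 nM and this is a limit and not a number. Compound 1, compound 2 and compound 3 also read as limits and not as numbers in the Vero assay so no new step can be read among them. In a physicochemical assay for solubility, read by nephelometry, at pH 7.4 (on this read-out higher numbers stand for higher solubility and lower numbers for lower solubility), compound 3 gives 62 ug/mL and compound 4 gives 61 ug/mL and these two values lie within the scatter of each other. In the Vero assay the compounds shown leave open where a measured half-maximal cytotoxic concentration would fall for any of them, since all share one reading: the limit of > 75000 nM in the Vero assay, at which 4 of the 4 values shown sit.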